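Notes on replacing propanoyl with (1H-pyrazol-4-yl)carbonyl

The source may report more compounds than this note shows. Statements on the series, on what has been measured and on what is new or still open speak of the compounds shown alone.

Measured so far in an ADME assay on microsomes (Homo sapiens) for metabolic stability; a lower number here means that the compound disappears faster, a higher number that the compound lasts longer:
- compound 1 `Cc1ccc(C2CC=NN2C(=O)C(C)(C)C)cc1F`: 0.267 h
- compound 2 `CCC(=O)N1CCC(C(=O)N2N=CCC2c2ccccc2)CC1`: > 2.75 h (a limit)

Compound 2 stands at > 2.75 h in this assay, which is a limit of the assay and not a number. Of the two measured compounds, only compound 1 has a numerical half-life.

The next compound is compound 3 `O=C(c1cn[nH]c1)N1CCC(C(=O)N2N=CCC2c2ccccc2)CC1`, and its difference from compound 2 is 1H-pyrazol-4-yl in place of ethyl on a carbonyl carbon. In words, 1H-pyrazol-4-yl takes the place of ethyl on a carbonyl carbon, turning propanoyl into (1H-pyrazol-4-yl)carbonyl. For the measured compounds named here, no measured step shows the size of such a change. The expected at least 1.1-fold lower number from compound 2 to compound 3 (0.04 log units; that floor lies within the scatter) is small, downward if anything, and not expected to go beyond the usual scatter. Compound 3 is estimated at 2.5 h, with an expected range of 1.2 h to 5 h.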

Compound 3, half-life: > 2.75 h
Compound 3 was reported as a limit; the forecaster's own chance of this, stated with the estimate: 50%; middle value at least 1.1-fold (0.04 log units) away from the limit.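

No step from compound 2 to compound 3 can be read in this assay, because both values are limits of the assay and not numbers: the limit of > 2.75 h in this assay, at which 2 of the 3 values shown sit.

As far as these compounds go, whether 1H-pyrazol-4-yl in place of ethyl on a carbonyl carbon changes the half-life at all remains open.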